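Inverting a ring stereocentre on the way from compound 3

The source may hold more compounds than are shown below. What is called first, only, known or untested is meant among the compounds shown, and "the series" means these compounds.

Compound 1, `O[C@@H]1c2cc(OCc3ccc4ccccc4n3)ccc2OC[C@@H]1Cc1cccnc1`, gives 38000 nM.
Compound 2, `O[C@@H]1c2cc(OCc3ccc4ccccc4n3)ccc2OC[C@H]1Cc1cccnc1`, gives 16000 nM.
Compound 3, `CC(Oc1ccc2c(c1)OC[C@H](Cc1ccccn1)[C@@H]2O)c1ccc2ccccc2n1`, gives 3300 nM.

All three were tested in an assay on isolated protein for inhibition of leukotriene B4 receptor 1 (Homo sapiens); a higher number here means a weaker inhibitor, a lower number a stronger inhibitor. Compound 3 stands at the lowest number of the three; compound 2 lies nearest to it and compound 1 furthest away, both gaps beyond the scatter. Compound 4, `CC(Oc1ccc2c(c1)OC[C@@H](Cc1ccccn1)[C@@H]2O)c1ccc2ccccc2n1`, has not yet been measured. It differs from compound 3 only in this: the two compounds have the same atoms and bonds; at least one stereo element is drawn with a configuration in one of them and without one in the other: 1 of 3 stereo elements differ; a stereocentre at a saturated ring carbon is drawn S in compound 3 and R in compound 4.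

Going by the values given here, one measured step bears on this change. Compounds 1 and 2 share the same atoms and bonds, and the step of a 2.4-fold lower number from compound 1 to compound 2 (0.38 log units; beyond the scatter) shows that the number moved down modestly when a ring stereocentre drawn S became R, a difference that rests on (the fact that compounds 1 and 2 differ only in the configuration as drawn). The same kind of inversion separates compound 3 from compound 4, so a modest move in the same direction is expected, although a single precedent in a different pair leaves the size uncertain.

Compound 4 is therefore estimated to show a step of a 2.1-fold lower number from compound 3 to compound 4 (0.31 log units; beyond the scatter) in this assay. The value of compound 4 is expected to be 1600 nM, with a range from 500 nM to 6000 nM.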

Compound 4, inhibition constant: 240 nM
Estimate against measurement, compound 4: 6.7-fold (0.82 log units) above; measured number outside the range, below it.
By their numbers in this assay, from the lowest: compound 4; then compound 3; then compound 2; then compound 1.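

The inversion of this ring stereocentre turns out to matter far more here than the earlier pair suggested: in this assay the change gives a 14-fold lower number from compound 3 to compound 4 (1.14 log units; beyond the scatter), whereas the same kind of change from S to R gave only a 2.4-fold lower number from compound 1 to compound 2 (0.38 log units; beyond the scatter). The direction is the same in both pairs, with the R form carrying the lower number and neither pair going against this, so the size of the step depends on the compounds in which the inversion is made. Nothing in the atoms and bonds separates the two compounds of the new pair, so the step belongs to the configuration as drawn at this one place: the fact that one of compounds 3 and 4 is drawn with a defined configuration and the other without, at the place where they differ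

The two pairs differ from each other elsewhere in their structures as well, and the compounds shown do not separate those differences, so it remains open which of them goes with the larger step. As far as these compounds go, it also remains open whether the inversion would keep this size if a carboxylic acid or an amine stood in place of the hydroxyl group on the shared core.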